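A Further Aryl Swap in a Series

The source may report more compounds than this note shows. Statements on the series, on what has been measured and on what is new or still open speak of the compounds shown alone.

Of the compounds shown here, three that share one core have been tested in an assay on CHO cells for displacement of a labelled ligand from adenosine receptor A3 (Homo sapiens), read by scintillation counting, with a stated time of 120 min, tested at 10 uM; on this read-out higher numbers stand for more inhibition at the one concentration tested (going by the name of the read-out) and lower numbers for less inhibition. Compound 1 `COc1ccc(N2CCN(Cc3csc(N)c3C(=O)c3ccc(Cl)cc3)CC2)cc1` gives 0%. Compound 2 `Nc1scc(CN2CCN(c3cccc(C(F)(F)F)c3)CC2)c1C(=O)c1ccc(Cl)cc1` gives 0%, level with compound 1 and together with it the lowest of the three numbers. Compound 3 `Nc1scc(CN2CCN(c3cc(F)cc(F)c3)CC2)c1C(=O)c1ccc(Cl)cc1` gives 2%. The three differ only in the group on the amine nitrogen in the ring, and each such change left the number essentially where it was: no change at the digits printed from compound 1 to compound 2 (within the scatter), a number 2 percentage points higher from compound 1 to compound 3 (within the scatter) and a number 2 percentage points higher from compound 2 to compound 3 (within the scatter), all within the scatter.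

Compound 4 `Nc1scc(CN2CCN(c3c(F)cc(F)cc3F)CC2)c1C(=O)c1ccc(Cl)cc1` differs from compound 2 in the same place: 2,4,6-trifluorophenyl in place of 3-(trifluoromethyl)phenyl on an amine nitrogen in a ring. Going by the values given here, the two steps that touch compound 2, the one arriving from compound 1 and the one leading to compound 3, both lie within the scatter, so in this assay the expected step is a number 1 percentage points higher from compound 2 to compound 4 (within the scatter), which is none beyond the scatter. Compound 4 is therefore estimated at 1%, with a range from -5% to 10%.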

Compound 4, a percentage reported as inhibition, at one concentration (the size of the read-out at that concentration, not a potency): 0%
For compound 4 the middle estimate is 1 percentage points above the measured one, and the stated range covers the measured number.
By their numbers in this assay, from the lowest: compounds 1, 2, 4 and 3 (each within the scatter of the next).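

In this assay, the 2,4,6-trifluorophenyl group joins the other aryl groups on this amine nitrogen without moving the number out of the scatter (first no change at the digits printed from compound 2 to compound 4 (within the scatter), then no change at the digits printed from compound 1 to compound 4 (within the scatter), and last a number 2 percentage points lower from compound 3 to compound 4 (within the scatter)). So a fourth substitution pattern on the aromatic ring at this position, now with three fluorines on the ring itself in place of a trifluoromethyl group, gives the same flat picture across compounds 1 to 4. Nothing shown offers a reason for this flatness.

On these data alone, all four compounds carry a six-membered aromatic ring of carbon only at this position, so the effect of a pyridine ring, a benzyl group or a plain alkyl chain there remains open. So does the effect of a carboxylic acid or an amine on the aromatic ring.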